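The source may report more compounds than this note shows. Statements on the series, on what has been measured and on what is new or still open speak of the compounds shown alone.

Measured so far:
compound 1, `COc1cc(/C=C\c2ccc(C(C)(C)C)cc2)cc(OC)c1OC`: a functional assay on HT-29 cells (Homo sapiens) for cytotoxicity (a lower number here means that less compound is needed, a higher number that more compound is needed for the effect), 8.8 uM
compound 2, `COc1cc(/C=C\c2ccc(SC)cc2)cc(OC)c1OC`: 1.8 uM

Compound 2 stands at the lowest of the two numbers; its nearest neighbour is compound 1, reached by the step of a 4.9-fold lower number from compound 1 to compound 2 (0.69 log units; beyond the scatter), a change of one group on the aromatic carbon. Compound 3, `COc1cc(/C=C/c2ccc(SC)cc2)cc(OC)c1OC`, differs from compound 2 in this way: the two compounds have the same atoms and bonds and differ only in configuration as drawn: 1 of 1 stereo elements differ; a double bond is drawn Z in compound 2 and E in compound 3. Going by the values given here, no measured step concerns a change of configuration, so the single step from compound 1 to compound 2 gives no guide to size or direction here, and the estimate for compound 3 must be wide. Compound 3 is expected to move by an 11-fold higher number from compound 2 to compound 3 (1.05 log units; beyond the scatter); the estimate for compound 3 is 20 uM, within 2 uM to 150 uM.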

Compound 3, concentration for half-maximal effect: 8.3 uM
Compound 3: the middle estimate sits 2.4-fold (0.38 log units) above what was measured; the range from low to high includes it.
By their numbers in this assay, from the lowest: compound 2; then compounds 3 and 1 (each within the scatter of the next).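

Changing the double bond from Z to E with methylsulfanyl held in place gives a 4.6-fold higher number from compound 2 to compound 3 (0.66 log units; beyond the scatter) in this assay. Going by these compounds alone, the earlier step showed only that the group on the aromatic carbon matters; this one shows that the configuration of the double bond also moves the number beyond the scatter, and for this pair the Z form has the lower number. The step can be tied to configuration alone because nothing else changes: the fact that compounds 2 and 3 differ only in the configuration as drawn

On these data alone, whether Z also gives the lower number with tert-butyl remains open. So does the size of the configuration step with an amine or a carboxylic acid on the same aromatic carbon.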